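Methylamino for Methoxy on a Weak Nucleoside Inhibitor

The source may hold more compounds than are shown below. What is called first, only, known or untested is meant among the compounds shown, and "the series" means these compounds.

Three compounds share one core and differ at a single aromatic carbon. Compound 1, `COc1ncnc2c1c(I)cn2[C@@H]1O[C@H](CO)[C@@H](O)[C@H]1O`, carries an iodo group there; in a functional assay on A549 cells (Homo sapiens), read by MTT assay, with a stated time of 72 h (a higher number here means a weaker inhibitor, a lower number a stronger inhibitor), compound 1 reaches only the limit > 20000 nM. Compound 2, `C#Cc1cn([C@@H]2O[C@H](CO)[C@@H](O)[C@H]2O)c2ncnc(OC)c12`, carries ethynyl instead, and in this assay compound 2 gives 8160 nM. Compound 3, `COc1ncnc2c1c(-c1ccccc1)cn2[C@@H]1O[C@H](CO)[C@@H](O)[C@H]1O`, carries phenyl, and in this assay compound 3 again reaches only the limit > 20000 nM. Swapping iodo for ethynyl gives an at least 2.4-fold lower number from compound 1 to compound 2 (0.38 log units; beyond the scatter), whereas moving on to phenyl gives an at least 2.4-fold higher number from compound 2 to compound 3 (0.38 log units; beyond the scatter); the direct comparison a step that the two limits leave unreadable from compound 1 to compound 3 cannot be read because both values sit at the limit of > 20000 nM in this assay, at which 2 of the 3 values shown sit. Compound 3 thus stands at the weaker end of what has been measured, with no number, only a limit.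

Compound 4, `CNc1ncnc2c1c(-c1ccccc1)cn2[C@@H]1O[C@H](CO)[C@@H](O)[C@H]1O`, keeps the phenyl and alters a different place: methylamino in place of methoxy on an aromatic carbon. For the measured compounds named here, none of the measured steps touches this position, so nothing measured bears on the size or direction of the change. With no guide, the expected step is a number no higher from compound 3 to compound 4 (the limit leaves the size open), essentially no movement beyond the scatter. The estimate for compound 4 in this assay is 20000 nM, within 5000 nM to 60000 nM, with a real chance that only a limit is reported again.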

Compound 4, half-maximal inhibitory concentration: > 20000 nM
Compound 4 ended at the assay's limit (the forecaster's own chance of this, stated with the estimate: 60%); the middle value sits exactly at the limit.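

In this assay compound 4 gives > 20000 nM, which is a limit and not a number. Compound 3 also stands at a limit, so the step between these two compounds, methylamino in place of methoxy, cannot be read: the limit of > 20000 nM in this assay, at which 3 of the 4 values shown sit. The compounds shown leave open whether this swap moves the number at all, and in which direction.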